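The source may hold more compounds than are shown below. What is called first, only, known or untested is meant among the compounds shown, and "the series" means these compounds.

In a functional assay on A549 cells (Homo sapiens) for cytotoxicity, read by MTT assay, with a stated time of 72 h (on this read-out lower numbers stand for stronger inhibition and higher numbers for weaker inhibition), three compounds sharing one core have been measured. Compound 1 `COc1cccc(/C=C2\CCC/C(=C\c3cccc(O)c3)C2=O)c1OC` gives only a limit, > 20000 nM. Compound 2 `COc1ccc(/C=C2\CCC/C(=C\c3cccc(OC)c3OC)C2=O)cc1OC` gives 14400 nM, and compound 3 `COc1ccc(/C=C2\CCC/C(=C\c3ccc(Cl)cc3)C2=O)cc1OC` gives 10100 nM, so compound 3 stands within the usual scatter of compound 2. Compound 4 `COc1cccc(/C=C2\CCC/C(=C\c3ccc(OC)c(OC)c3)C2=O)c1` has not yet been measured. It carries 3-methoxyphenyl in place of 4-chlorophenyl on a double-bonded chain carbon bound to a double-bonded ring carbon. Among the compounds with values here, no measured pair isolates this change, so the expectation leans on compound 2 at 14400 nM, which has no 4-chlorophenyl. In this assay the expected step is a 1.2-fold higher number from compound 3 to compound 4 (0.07 log units; within the scatter), slightly toward weaker inhibition but within the scatter. For compound 4 the estimated value is 12000 nM, with an expected range of 6000 nM to 24000 nM.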

Compound 4, half-maximal inhibitory concentration: 6700 nM
Compound 4: middle estimate off by 1.8-fold (0.25 log units), on the high side; low and high end bracket the measured number.
By their numbers in this assay, from the lowest: compounds 4, 3 and 2 (each within the scatter of the next, the first and the last beyond it). At a limit, above all of these: compound 1.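

Across this assay, these are the first comparisons of compounds differing in one place. Putting 3-methoxyphenyl in place of 4-chlorophenyl on a double-bonded chain carbon bound to a double-bonded ring carbon gives a 1.5-fold lower number from compound 3 to compound 4 (0.18 log units; within the scatter) and so does not separate the two groups at this position. Hydrogen in place of methoxy on an aromatic carbon gives a 2.1-fold lower number from compound 2 to compound 4 (0.33 log units; beyond the scatter) as a modest step, the only one here that reads as a change. As far as these compounds go, whether an amine or a carboxylic acid at this position would shift the number remains open. Nothing shown explains either step.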